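Homologation of the hydroxycyclobutyl amine link

The source may report more compounds than this note shows. Statements on the series, on what has been measured and on what is new or still open speak of the compounds shown alone.

Two stereoisomers share one core. Compound 1 `N#Cc1cnc(NCc2cnccc2C(F)(F)F)cc1N[C@H]1C[C@@H](O)C1` gives 500 nM in an assay on isolated protein for inhibition of protein kinase C theta type (Homo sapiens), read by TR-FRET, with a stated time of 2 h; on this read-out lower numbers stand for stronger inhibition and higher numbers for weaker inhibition. Among the compounds with values here, compound 2 `N#Cc1cnc(NCc2cnccc2C(F)(F)F)cc1N[C@H]1C[C@H](O)C1` gives 900 nM in this assay; this is the higher of the two numbers measured so far, but the only step known, a 1.8-fold higher number from compound 1 to compound 2 (0.26 log units; within the scatter), lies within the scatter, and its whole content is the fact that compounds 1 and 2 differ only in the configuration as drawn, so the two are not separable on these numbers.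

Compound 3 `N#Cc1cnc(NCc2cnccc2C(F)(F)F)cc1NC[C@H]1C[C@@H](O)C1` is not yet measured. It differs from compound 2 by (3-hydroxycyclobutyl)methyl in place of 3-hydroxycyclobutyl on a nitrogen on an aromatic ring, which one bond further out reads as (3-hydroxycyclobutyl)amino to ((3-hydroxycyclobutyl)methyl)amino. Within the data shown here, no measured step bears on this change; the one step at hand is an inversion of both stereocentres, which says nothing about lengthening the link between the nitrogen and the ring. The expected step in this assay is therefore held loosely and set at a 1.7-fold higher number from compound 2 to compound 3 (0.22 log units; within the scatter), with room in both directions. Compound 3 is expected near 1500 nM in this assay, estimated between 400 nM and 6000 nM.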

Compound 3, half-maximal inhibitory concentration: 300 nM
The estimate for compound 3 lay 5.0-fold (0.70 log units) above the measured number; the measured number lies below the stated range.
By their numbers in this assay, from the lowest: compounds 3, 1 and 2 (each within the scatter of the next, the first and the last beyond it).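

Lengthening the link is accepted at this position: in this assay, (3-hydroxycyclobutyl)methyl in place of 3-hydroxycyclobutyl on a nitrogen on an aromatic ring gives a 3.0-fold lower number from compound 2 to compound 3 (0.48 log units; beyond the scatter), and this is the first step in the series that stands beyond the scatter. The same replacement read from the other stereoisomer gives a 1.7-fold lower number from compound 1 to compound 3 (0.22 log units; within the scatter), so the longer link stands clear of only one of the two 3-hydroxycyclobutyl compounds, and its size depends on which of them serves as the reference. These two readings differ although their starting points are related in one way only: the fact that compounds 1 and 2 differ only in the configuration as drawn.

How the configuration of the (3-hydroxycyclobutyl)methyl group itself bears on the number in this assay remains open, since compound 3 stands alone with this link and has no stereoisomer among the compounds shown. Also open, on these data alone, are a longer chain on the same nitrogen, such as (3-hydroxycyclobutyl)ethyl, and an amine or a carboxylic acid in place of the hydroxyl on the four-membered ring.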